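Removing the pyridin-2-yl group from compound 3

The source may hold more compounds than are shown below. What is called first, only, known or untested is meant among the compounds shown, and "the series" means these compounds.

Measured in a functional assay (aorta) with Oryctolagus cuniculus as the target; on this read-out higher numbers stand for weaker binding and lower numbers for tighter binding:
- compound 1 `COc1cc(C(C)=O)ccc1OCCCN1CCC(C(c2ccccc2)c2ccc(F)cc2)CC1`: 6.31 nM
- compound 2 `COc1cc(C(C)=O)ccc1OCCCN1CCC(C(c2ccc(F)cc2)C2CCCCC2)CC1`: 5.01 nM
- compound 3 `COc1cc(C(C)=O)ccc1OCCCN1CCC(C(c2ccc(F)cc2)c2ccccn2)CC1`: 158 nM

Compound 3 carries the highest number of the three, at 158 nM, and both other compounds lie beyond the scatter from it. The next structure, compound 4 `COc1cc(C(C)=O)ccc1OCCCN1CCC(Cc2ccc(F)cc2)CC1`, has hydrogen in place of pyridin-2-yl on a saturated chain carbon bound to an aromatic carbon and a saturated ring carbon.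

For the measured compounds named here, three measured steps concern this same place. Exchanging phenyl for cyclohexyl gave a 1.3-fold lower number from compound 1 to compound 2 (0.10 log units; within the scatter), so these two groups cannot be told apart in this assay. Pyridin-2-yl stands apart, with a 25-fold higher number from compound 1 to compound 3 (1.40 log units; beyond the scatter) and a 32-fold higher number from compound 2 to compound 3 (1.50 log units; beyond the scatter). None of these steps leaves the place with hydrogen alone, so the data contain no direct test of the change, and the expectation is uncertain. Since only compound 3 stands high, at 158 nM, a moderate move back towards compound 1 and compound 2 seems more likely than a further rise, though probably not all the way. The expected change is a 4.0-fold lower number from compound 3 to compound 4 (0.60 log units; beyond the scatter), towards a lower number. The estimated value for compound 4 is 40 nM, with an expected range from 8 nM to 200 nM.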

Compound 4, dissociation constant: 20 nM
Compound 4: the middle estimate sits 2.0-fold (0.30 log units) above what was measured; measured number inside the range.
By their numbers in this assay, from the lowest: compounds 2 and 1 (each within the scatter of the next); then compound 4; then compound 3.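

In this assay, the place on the saturated chain carbon bound to an aromatic carbon and a saturated ring carbon turns out not to need a second ring, and removing pyridin-2-yl recovers much of the ground lost with it (a 7.9-fold lower number from compound 3 to compound 4 (0.90 log units; beyond the scatter)), so the high number of compound 3 goes with that group rather than with the shared core. Hydrogen does not match the two other rings, though (a 3.2-fold higher number from compound 1 to compound 4 (0.50 log units; beyond the scatter); a 4.0-fold higher number from compound 2 to compound 4 (0.60 log units; beyond the scatter)), which places the groups in a clear order: phenyl and cyclohexyl, which cannot be told apart, give the lowest numbers, then hydrogen, then pyridin-2-yl, so a ring here can lower or raise the number relative to hydrogen. Nothing in the available data gives a reason for this order.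

The compounds shown leave open whether pyridin-3-yl or pyridin-4-yl at this place would stand with phenyl or with pyridin-2-yl. They also leave open whether a group as small as methyl or hydroxyl would move the number from that of compound 4 towards those of compound 1 and compound 2.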